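Aryl Variation at the Hydrazone Carbon of the Series

The source may report more compounds than this note shows. Statements on the series, on what has been measured and on what is new or still open speak of the compounds shown alone.

Compound 1 `CN(C)CCn1cnnc1-c1cc(Oc2ccc(NC(=O)N/N=C/c3ccc(Cl)cc3)cc2F)ccn1` serves as the anchor. In a functional assay on U-87MG ATCC cells (Homo sapiens) for cytotoxicity, read by MTT assay, with a stated time of 72 h (on this read-out higher numbers stand for weaker inhibition and lower numbers for stronger inhibition), compound 1 gives 1370 nM, the highest of the two numbers in hand; its nearest neighbour is compound 3 `CN(C)CCn1cnnc1-c1cc(Oc2ccc(NC(=O)N/N=C/c3c(O)ccc4ccccc34)cc2F)ccn1` at 620 nM, reached by a 2.2-fold lower number from compound 1 to compound 3 (0.34 log units; beyond the scatter). Compound 2 `CN(C)CCn1cnnc1-c1cc(Oc2ccc(NC(=O)N/N=C/c3ccc(O)c(O)c3)cc2F)ccn1` gives only a limit of the assay, > 100000 nM; (the limit of > 100000 nM in this assay, at which 1 of the 3 values shown sits). Compound 4 `COc1ccc(/C=N/NC(=O)Nc2ccc(Oc3ccnc(-c4nncn4CCN(C)C)c3)c(F)c2)c(OC)c1` carries 2,4-dimethoxyphenyl in place of 4-chlorophenyl on a carbon with a double bond to nitrogen. Both measured steps bear on this position: an at least 72-fold higher number from compound 1 to compound 2 (1.86 log units; beyond the scatter) was large, whereas an at least 160-fold lower number from compound 2 to compound 3 (2.20 log units; beyond the scatter) was also large, so the ring placed here matters greatly. The entering group has no hydrogen-bond donors, unlike the 3,4-dihydroxyphenyl of compound 2, so a collapse to the limit is not expected. A modest step, a 1.5-fold higher number from compound 1 to compound 4 (0.16 log units; within the scatter), is expected. Compound 4 is estimated at 2000 nM, within 500 nM to 8000 nM.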

Compound 4, half-maximal inhibitory concentration: 12600 nM
The estimate for compound 4 lay 6.3-fold (0.80 log units) below the measured number; measured number outside the range, above it.
By their numbers in this assay, from the lowest: compound 3; then compound 1; then compound 4. At a limit, above all of these: compound 2.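

Two groups with 0 hydrogen-bond donors at this carbon still give clearly different numbers, so the absence of donors does not by itself hold the number near that of compound 1 (a 9.2-fold higher number from compound 1 to compound 4 (0.96 log units; beyond the scatter)). 2,4-Dimethoxyphenyl falls well short of 2-hydroxynaphthalen-1-yl (a 20-fold higher number from compound 3 to compound 4 (1.31 log units; beyond the scatter)) but remains ahead of 3,4-dihydroxyphenyl (an at least 7.9-fold lower number from compound 2 to compound 4 (0.89 log units; beyond the scatter)). The value for compound 2 is a limit of the assay, not a number: the limit of > 100000 nM in this assay, at which 1 of the 4 values shown sits.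

On these data alone, whether the loss follows from the methoxy groups themselves or from their placement stays open. Also open, as far as these compounds go, is what 4-methoxyphenyl or 4-(dimethylamino)phenyl would give at this carbon.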